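The source may hold more compounds than are shown below. What is called first, only, known or untested is meant among the compounds shown, and "the series" means these compounds.

Measured so far:
compound 1 `CS(=O)(=O)c1nn2cc(-c3cc4ccccc4o3)nc2s1`; in an assay for antagonist activity at proteinase-activated receptor 4 (Homo sapiens), with stated times of 5 min, 50 s and 15 min, in the presence of a further agent that is not named here (a higher number here means a weaker inhibitor, a lower number a stronger inhibitor), compound 1 gives > 30000 nM.
compound 2 `COc1nn2cc(-c3cc4cccc(OC)c4o3)nc2s1`; compound 2 gives 240 nM.
compound 3 `COc1cc(OC)c2cc(-c3cn4nc(OC)sc4n3)oc2c1`; compound 3 gives 74 nM.

Compound 1 stands apart: its result is only a limit of this assay (the limit of > 30000 nM in this assay, at which 1 of the 3 values shown sits), not a number. Compounds 2 and 3, which carry methoxy rather than methylsulfonyl on the shared core, each give a measured value. Compound 4 `CC(C)Oc1nn2cc(-c3cc4ccccc4o3)nc2s1` differs from compound 1 in one place: isopropoxy in place of methylsulfonyl on an aromatic carbon. Within the data shown here, no step between two measured compounds is at hand, so the size of this step can only be judged from what the three values show. The change is expected to move toward stronger inhibition by a step well beyond the scatter, an at least 50-fold lower number from compound 1 to compound 4 (1.69 log units; beyond the scatter). For compound 4 the estimated value is 600 nM, expected to lie between 100 nM and 6000 nM.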

Compound 4, half-maximal inhibitory concentration: > 30000 nM
Compound 4: a limit, no number (the forecaster's own chance of this, stated with the estimate: 15%); middle value at least 50-fold (1.69 log units) away from the limit.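

Compound 1 and compound 4 both give only a limit, not a number, so the step between them cannot be read: the limit of > 30000 nM in this assay, at which 2 of the 4 values shown sit.

The compounds shown leave open whether isopropoxy or methylsulfonyl on the shared core gives the stronger inhibitor.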